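Chloro in Place of Fluoro, Seen Twice on One Core

The compounds below may be only part of what the source reports. "The series", "measured", "known", "first", "only" and "open" are said of these compounds alone.

Of the compounds shown here, three have been tested in a functional assay on NCI-H1975 cells (Homo sapiens) for inhibition, read by MTT assay, with a stated time of 72 h; a lower number here means a stronger inhibitor, a higher number a weaker inhibitor. Compound 1 `O=C(CSc1nc(Nc2ccccc2)c2ccccc2n1)Nc1cccc(F)c1` gives 6790 nM. Compound 2 `O=C(CSc1nc(Nc2ccccc2)c2ccccc2n1)Nc1cccc(Cl)c1` carries the change (chloro in place of fluoro on an aromatic carbon), which sits meta to a large group, and in this assay compound 2 gives 8460 nM. Among the compounds with values here, the step of a 1.2-fold higher number from compound 1 to compound 2 (0.10 log units; within the scatter) is the only measured example of this swap. Compound 3 `C=CC(=O)Nc1cccc(NC(=O)CSc2nc(Nc3ccccc3F)c3ccccc3n2)c1` has a different core; the difference between the core of compound 3 and the core of compound 1 is not broken down here. In this assay compound 3 gives 6580 nM, and its numbers against compound 1 and compound 2 lie within the scatter.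

Compound 4 `C=CC(=O)Nc1cccc(NC(=O)CSc2nc(Nc3ccccc3Cl)c3ccccc3n2)c1` has not been measured. It differs from compound 3 by chloro in place of fluoro on an aromatic carbon. Within the data shown here, this is the same kind of change as the one from compound 1 to compound 2, but not the same: there the chloro took a place meta to a large group, here it takes a place ortho to a large group. Because the measured step of a 1.2-fold higher number from compound 1 to compound 2 (0.10 log units; within the scatter) stayed within the scatter, the expectation is that the step of a 1.1-fold higher number from compound 3 to compound 4 (0.06 log units; within the scatter) will also be small, with more room for a higher number. The estimate for compound 4 in this assay is 7500 nM, expected to fall between 4000 nM and 14000 nM.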

Compound 4, half-maximal inhibitory concentration: 10000 nM
Compound 4: middle estimate off by 1.3-fold (0.12 log units), on the low side, and the stated range covers the measured number.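

In this assay, putting chloro in place of fluoro on the 2-fluorophenyl group of compound 3 gives a 1.5-fold higher number from compound 3 to compound 4 (0.18 log units; within the scatter), a step too small to tell apart from the ordinary spread of repeated measurements. This does not show that chloro truly weakens these compounds, nor that the swap would behave the same way on any other core, since two small steps on two cores, with the chloro in a different place on each, make a very thin basis for a rule. What it does show is that, so far, this swap has made no clear difference on either core, and the two steps cannot be told apart from each other: the same change on two cores in this assay, a 1.2-fold higher number (0.10 log units; within the scatter) from compound 1 to compound 2 and a 1.5-fold higher number (0.18 log units; within the scatter) from compound 3 to compound 4, 1.2-fold (0.09 log units) apart, within the scatter of two such steps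

The compounds shown carry only fluoro or chloro at the position of the swap, so it remains open how a larger or quite different group, such as bromo, methyl or methoxy, would read out there. From the compounds shown here alone, an amine or a carboxylic acid at that position is also open, and either could show whether this part of the molecule can shift the number at all.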